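Replacing the Amide Substituent of Compound 1 in Macrophage Cytotoxicity

The source may hold more compounds than are shown below. What is called first, only, known or untested is meant among the compounds shown, and "the series" means these compounds.

Compound 1 `CCn1cc(C(=O)NCc2ccc(OC)cc2)c(=O)c2ccc(C(F)(F)F)cc21`: > 100000 nM
Compound 2 `NC(=O)C1CCN(c2cc3c(cc2F)c(=O)c(C(=O)NCc2ccco2)cn3C2CC2)CC1`: > 100000 nM

Both entries are limits of the assay and not numbers. In an ADME assay on J774.1 cells (Mus musculus) for cytotoxicity, read by resazurin assay, with a stated time of 48 h (on this read-out lower numbers stand for stronger inhibition and higher numbers for weaker inhibition), compound 1 gives > 100000 nM, which is a limit. Compound 2 gives > 100000 nM, also a limit. Compound 1 therefore has no numerical value to anchor a comparison, and the record so far amounts to the limit of > 100000 nM in this assay, at which 2 of the 2 values shown sit.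

Compound 3 `CCn1cc(C(=O)Nc2ccc(Cl)c(F)c2)c(=O)c2ccc(C(F)(F)F)cc21` retains the core of compound 1 and carries 4-chloro-3-fluorophenyl in place of 4-methoxybenzyl on an amide-type nitrogen. For the measured compounds named here, no pair of measured compounds differs in one place, so the size of this change in this assay can only be judged loosely. The expectation is a modest move, if any, toward stronger inhibition, leaving the result close to the limit. The expected change is an at least 1.4-fold lower number from compound 1 to compound 3 (0.15 log units; that floor lies within the scatter). A further reading at the limit would not be surprising. For compound 3 the estimated value is 70000 nM, with an expected range from 20000 nM to 100000 nM.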

Compound 3, half-maximal inhibitory concentration: > 100000 nM
Compound 3 ended at the assay's limit; the forecaster's own chance of this, stated with the estimate: 55%; at least 1.4-fold (0.15 log units) between middle value and limit.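

Compound 1 and compound 3 both stand at a limit in this assay, and no step can be read between them. The compounds shown leave open whether 4-chloro-3-fluorophenyl in place of 4-methoxybenzyl changes the read-out at all, and at what concentration any of them would give a number, the record being: the limit of > 100000 nM in this assay, at which 3 of the 3 values shown sit.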